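A few compounds are considered here, and "the series" means these few. Any claim that something is new, unique, unknown or untested is made for them only; others in the source may bear on it.

Three close relatives of one shared core have been measured in a functional assay for inhibition of sodium/hydrogen exchanger (Oryctolagus cuniculus); on this read-out higher numbers stand for weaker inhibition and lower numbers for stronger inhibition. Compound 1 `Cc1cc(Sc2ccncc2)c(S(C)(=O)=O)cc1C(=O)N=C(N)N` gives 13 nM in this assay. Compound 2 `CCOc1cc(C)c(C(=O)N=C(N)N)cc1S(C)(=O)=O` gives 19 nM in this assay. Compound 3 `Cc1cc(Oc2ccccc2Cl)c(S(C)(=O)=O)cc1C(=O)N=C(N)N` gives 14 nM in this assay, the second highest of the three numbers; its nearest neighbour is compound 1 and its furthest is compound 2, and both gaps lie within the scatter. Compound 4 `Cc1cc(N2CCC(N)CC2)c(S(C)(=O)=O)cc1C(=O)N=C(N)N` has not yet been measured. It differs from compound 3 in one place: 4-aminopiperidin-1-yl in place of 2-chlorophenoxy on an aromatic carbon. Three measured steps, all exchanges at this same position of the core, bear on the question: a 1.1-fold higher number from compound 1 to compound 3 (0.03 log units; within the scatter), a 1.4-fold lower number from compound 2 to compound 3 (0.13 log units; within the scatter) and a 1.5-fold higher number from compound 1 to compound 2 (0.16 log units; within the scatter). Each of them stays within the scatter, even though the groups exchanged range from ethoxy to (pyridin-4-yl)sulfanyl to 2-chlorophenoxy. The change to 4-aminopiperidin-1-yl is therefore expected to give no step beyond the scatter, estimated as a 1.1-fold higher number from compound 3 to compound 4 (0.03 log units; within the scatter). Compound 4 is thus expected to give about 15 nM in this assay, with a range from 5 nM to 45 nM.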

Compound 4, half-maximal inhibitory concentration: 9.8 nM
For compound 4 the middle estimate is 1.5-fold (0.18 log units) above the measured one; measured number inside the range.
By their numbers in this assay, from the lowest: compounds 4, 1, 3 and 2 (each within the scatter of the next).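

Putting 4-aminopiperidin-1-yl at this position gives a 1.4-fold lower number from compound 3 to compound 4 (0.15 log units; within the scatter) when it replaces 2-chlorophenoxy, a 1.9-fold lower number from compound 2 to compound 4 (0.29 log units; within the scatter) when it replaces ethoxy and a 1.3-fold lower number from compound 1 to compound 4 (0.12 log units; within the scatter) when it replaces (pyridin-4-yl)sulfanyl. Every earlier group at this position was joined to the aromatic carbon through an oxygen or a sulfur, whereas this one is joined through a ring nitrogen and brings a non-aromatic ring carrying an amine. Even this larger change of type leaves the number within the scatter of all three earlier compounds.

Nothing shown here explains why such different groups give such similar numbers. As far as these compounds go, it also remains open whether a carboxylic acid, a longer chain ending in an amine or a bare hydrogen at this position would stay within the scatter too.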